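The source may hold more compounds than are shown below. What is called first, only, known or untested is meant among the compounds shown, and "the series" means these compounds.

Values in a functional assay on DU-145 cells (Homo sapiens) for cytotoxicity, read by sulforhodamine B assay, with a stated time of 48 h; a lower number here means a stronger inhibitor, a higher number a weaker inhibitor:
compound 1 `CC(=O)OC[C@H]1O[C@@H](n2cc(Cn3cc([N+](=O)[O-])c4ccccc43)nn2)[C@H](OC(C)=O)[C@@H](OC(C)=O)[C@@H]1OC(C)=O` — 60900 nM
compound 2 `CC(=O)OC[C@H]1O[C@@H](n2cc(CN3C(=O)/C(=C\c4ccc(N(C)C)cc4)c4ccccc43)nn2)[C@H](OC(C)=O)[C@@H](OC(C)=O)[C@@H]1OC(C)=O` — 10100 nM
compound 3 `CC(=O)OC[C@H]1O[C@@H](n2cc(CN3C(=O)/C(=C/c4ccc(N(C)C)cc4)c4ccccc43)nn2)[C@H](OC(C)=O)[C@@H](OC(C)=O)[C@@H]1OC(C)=O` — 11200 nM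

Compound 2 and compound 3 give numbers within the scatter of each other, a 1.1-fold higher number from compound 2 to compound 3 (0.04 log units; within the scatter), while compound 1 gives the highest number of the three, well apart from compound 2. That compounds 2 and 3 sit so close together is consistent with the fact that compounds 2 and 3 differ only in the configuration as drawn: the drawn geometry of the exocyclic double bond does not move the number.

Compound 4 `CCC/C=C1\C(=O)N(Cc2cn([C@@H]3O[C@H](COC(C)=O)[C@@H](OC(C)=O)[C@H](OC(C)=O)[C@H]3OC(C)=O)nn2)c2ccccc21` is not yet measured. Against compound 2 the change is propyl in place of 4-(dimethylamino)phenyl on a double-bonded chain carbon bound to a double-bonded ring carbon. Within the data shown here, no measured step concerns this position; the one measured step, a 1.1-fold higher number from compound 2 to compound 3 (0.04 log units; within the scatter), alters only the configuration at that double bond and leaves the 4-(dimethylamino)phenyl group in place, so it gives no direct guide. Compound 1 shows that a different substitution pattern on the shared core can carry a much higher number, but it differs from compound 2 in more than one place.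

With the aryl group removed and only propyl remaining, compound 4 is expected to give a higher number than compound 2 in this assay, a 3.0-fold higher number from compound 2 to compound 4 (0.47 log units; beyond the scatter). The estimate for compound 4 is 30000 nM, with a range from 10000 nM to 90000 nM.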

Compound 4, half-maximal inhibitory concentration: 26600 nM
Compound 4: middle estimate off by 1.1-fold (0.05 log units), on the high side, within the range that was stated.
By their numbers in this assay, from the lowest: compounds 2 and 3 (each within the scatter of the next); then compound 4; then compound 1.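

In this assay, the earlier step at this double bond altered only its drawn configuration, and the 4-(dimethylamino)phenyl group stayed in place. Among these compounds, exchanging the group itself does move the number: the change to propyl gives a 2.6-fold higher number from compound 2 to compound 4 (0.42 log units; beyond the scatter), so the substituent on the double-bonded chain carbon bound to a double-bonded ring carbon matters in a way that the drawn geometry, in the one pair that shows it, did not. The step is modest, however, and shows that in this pair an aromatic ring at this place is not needed for a number within that distance of compound 2; the information at hand offers no measured property that accounts for the step.

This single exchange removes the aromatic ring, the dimethylamino nitrogen and part of the heavy-atom count together, so the contribution of each stays unresolved. Open questions are how an unsubstituted phenyl, a phenyl bearing a carboxylic acid or a longer chain such as hexyl would compare with compound 2 and compound 4, and whether the drawn geometry of the double bond counts when propyl is the substituent.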